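The source may hold more compounds than are shown below. What is called first, only, known or untested is meant among the compounds shown, and "the series" means these compounds.

Measured compounds, with their growth-inhibition numbers:
compound 1 `C[Se]/C(=N\C(=O)c1cc2ccccc2s1)NC(=O)c1cc2ccccc2s1` with 32400 nM
compound 2 `CS/C(=N\C(=O)c1sccc1Cl)NC(=O)c1sccc1Cl` with 37000 nM
compound 3 `C[Se]/C(=N\C(=O)c1ccco1)NC(=O)c1ccco1` with 8780 nM

In a functional assay on K562 cells (Homo sapiens) for cytotoxicity, read by MTT assay, with a stated time of 72 h (a lower number here means a stronger inhibitor of growth, a higher number a weaker inhibitor of growth), compound 3 stands lowest of the three. Compound 1 sits a step above it that lies beyond the scatter, and compound 2 a slightly larger step above, also beyond the scatter.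

Compound 4 `CS/C(=N\C(=O)c1ccco1)NC(=O)c1ccco1` differs from compound 3 in one place: a group of 2 heavy atoms (1 carbon, 1 sulfur; no ring) in place of a group of 2 heavy atoms (1 carbon, 1 selenium; no ring), on a carbon with a double bond to nitrogen, methylsulfanyl entering on a carbon with a double bond to nitrogen whose other neighbours are amide-type nitrogen and amide-type nitrogen. Going by the values given here, no measured pair shows this exchange alone; compounds 1 and 2 carry it together with a different acyl group, so their gap cannot be assigned to it. A small step toward a higher number is expected, likely within the scatter. Compound 4 is therefore estimated at 15000 nM, between 4000 nM and 50000 nM, an expected step of a 1.7-fold higher number from compound 3 to compound 4 (0.23 log units; within the scatter).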

Compound 4, concentration for 50% growth inhibition: 64800 nM
Compound 4: middle estimate off by 4.3-fold (0.64 log units), on the low side, and the stated range ends below it.
By their numbers in this assay, from the lowest: compound 3; then compounds 1, 2 and 4 (each within the scatter of the next).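

In this assay, going by these compounds alone, the pair gives the first clean reading of this position: with both acyl groups unchanged, putting methylsulfanyl in place of the selenium-containing group on a carbon with a double bond to nitrogen gives a 7.4-fold higher number from compound 3 to compound 4 (0.87 log units; beyond the scatter), a step beyond the scatter. The exchange at this place alone is therefore enough to weaken growth inhibition. Nothing measured here accounts for the step. Whether it has a similar size with other acyl groups cannot be read from the compounds shown, and the effect of a methoxy group or an amine on this carbon remains open.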